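A few compounds are considered here, and "the series" means these few. Any claim that something is new, unique, unknown or untested is made for them only; others in the source may bear on it.

Measured in an ADME assay on HL-60 cells (Homo sapiens) for cytotoxicity, read by MTT assay, with a stated time of 24 h (a higher number here means a weaker inhibitor, a lower number a stronger inhibitor), each value a limit:
- compound 1 `CN1CCC=C(c2ccc(CN(C)Cc3ccccc3)cc2)C1`: > 50000 nM
- compound 2 `CN1CCC=C(c2ccc(CN(C)C/C=C/c3ccccc3)cc2)C1`: > 50000 nM
- compound 3 `CN1CCC=C(c2ccc(CN(C)CCCc3ccccc3)cc2)C1`: > 50000 nM

The series stands at the limit of > 50000 nM in this assay, at which 3 of the 3 values shown sit, so compound 2 has no number to start from. Compound 4 `CN(C/C=C/c1ccccc1)Cc1ccc(-c2cccnc2)cc1` departs from compound 2 in one place: a group of 6 heavy atoms (5 carbon, 1 nitrogen; one six-membered aromatic ring with 1 hetero atom) in place of a group of 7 heavy atoms (6 carbon, 1 nitrogen; one six-membered non-aromatic ring with 1 hetero atom), on an aromatic carbon. The change lies on an aromatic carbon of a six-membered aromatic ring of carbon only, para to a large group.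

The measured steps, a step that the two limits leave unreadable from compound 1 to compound 2, a step that the two limits leave unreadable from compound 1 to compound 3 and a step that the two limits leave unreadable from compound 2 to compound 3, all alter the chain on the amine nitrogen, and none has a readable size. None of them bears on this change.

In this assay, no direction can be expected, and the expected step is a number no higher from compound 2 to compound 4 (the limit leaves the size open). The estimate for compound 4 is 50000 nM, with an expected range of 20000 nM to 100000 nM.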

Compound 4, half-maximal inhibitory concentration: 44000 nM
Compound 4: the middle estimate sits 1.1-fold (0.06 log units) above what was measured; the range from low to high includes it.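

In this assay, going by these compounds alone, pyridin-3-yl on this aromatic carbon, para to a large group, gives the only value that is not a limit: compound 4 reads 44000 nM. The change gives an at least 1.1-fold lower number from compound 2 to compound 4 (0.05 log units; that floor lies within the scatter), so this position shows no shift that clears the scatter, and the true size stays unfixed. The steps on the amine chain cannot be read, and the other compounds stay limits: the limit of > 50000 nM in this assay, at which 3 of the 4 values shown sit.

Open, as far as these compounds go, is what a carboxylic acid or a primary amine on this aromatic carbon would give. Also open, from the compounds shown here alone, is whether phenethyl on the amine chain moves the number with pyridin-3-yl in place.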